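Nitrothiazole sulfides: from ester to benzylamine on the side chain

This account rests on a few compounds, and the source may have more. Where it says the series, first, only, none or still open, it means among the compounds named here.

Compound 1 `CC(=O)c1nc([N+](=O)[O-])c(Sc2cccc(Cl)c2Cl)s1` gives 9290 nM in a functional assay on HCT-116 cells (Homo sapiens) for antiproliferative activity, read by MTT assay, with a stated time of 72 h; a higher number here means a weaker inhibitor, a lower number a stronger inhibitor.
Compound 2 `CC(=O)c1nc([N+](=O)[O-])c(Sc2c(Cl)cccc2Cl)s1` gives 19300 nM in this assay.
Compound 3 `CCCC(=O)OC(C)c1nc([N+](=O)[O-])c(Sc2c(Cl)cncc2Cl)s1` gives 11700 nM in this assay.

Among these three numbers compound 3 holds the second highest; its value sits nearest that of compound 1 and furthest from that of compound 2, yet both gaps fall within the scatter, so no order can be read among them. Compound 4 `CC(NCc1ccccc1)c1nc([N+](=O)[O-])c(Sc2c(Cl)cncc2Cl)s1` differs from compound 3 in one place: benzylamino in place of (propylcarbonyl)oxy on a saturated chain carbon bound to an aromatic carbon and a saturated chain carbon. Among the compounds with values here, no measured pair shows what this kind of change does, so the data give no basis for a step in this assay beyond the scatter in either direction. The expected step of a 1.3-fold lower number from compound 3 to compound 4 (0.11 log units; within the scatter) is therefore small. Compound 4 is estimated at 9000 nM, in a range from 2500 nM to 32000 nM.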

Compound 4, half-maximal inhibitory concentration: 11800 nM
For compound 4 the middle estimate is 1.3-fold (0.12 log units) below the measured one; the range from low to high includes it.
By their numbers in this assay, from the lowest: compounds 1, 3, 4 and 2 (each within the scatter of the next, the first and the last beyond it).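

Within the data shown here, the one-place change shows a 1.0-fold higher number from compound 3 to compound 4 (0.00 log units; within the scatter) in this assay and so gives the first measured step on this saturated chain carbon. In this pair, benzylamino with its six-membered aromatic ring of carbon only cannot be told apart from (propylcarbonyl)oxy. No measured evidence bears on why these two groups read alike. The compounds shown leave open whether a carboxylic acid, a dimethylamino group or a hydroxyl on this carbon would also read alike. They also leave open how a longer chain in place of benzylamino would read.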